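From compound 2 to compound 4: an expected cytotoxicity limit

The compounds below may be only part of what the source reports. "The series", "measured", "known", "first", "only" and "open" are said of these compounds alone.

Three compounds sharing one core were tested in an ADME assay on Vero cells (Chlorocebus sabaeus) for cytotoxicity, read by resazurin assay, with a stated time of 3 days; on this read-out higher numbers stand for weaker inhibition and lower numbers for stronger inhibition. Compound 1 `CCCCOC(=O)Nc1cc2nc(C3CCCCC3)[nH]c2cc1N(CC)CCN(C)C` gives > 100 ug/mL, which is a limit of the assay rather than a number. Compound 2 `CCCC(C)OC(=O)Nc1cc2nc(C3CCCCC3)[nH]c2cc1N(CC)CC` gives > 100 ug/mL, again a limit. Compound 3 `O=C(Nc1cc2nc(C3CCCCC3)[nH]c2cc1N1CCCC1)c1ccc(Br)cc1` gives > 100 ug/mL, also a limit. Compound 2 thus stands at the limit of > 100 ug/mL in this assay, at which 3 of the 3 values shown sit, with no number setting it apart from the other two. Compound 4 `CCN(CC)c1cc2[nH]c(C3CCCCC3)nc2cc1NC(=O)c1cccc(Br)c1` differs from compound 2 by 3-bromophenyl in place of 1-methylbutoxy on a carbonyl carbon. Compound 3, which also carries an amide-type nitrogen on its carbonyl, sits at that same limit, so no step beyond the scatter is expected in this assay. Compound 4 is therefore expected to give 100 ug/mL, between 50 ug/mL and 200 ug/mL, most likely reported as a limit. The step of a number no higher from compound 2 to compound 4 (the limit leaves the size open) is expected to be none beyond the scatter.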

Compound 4, half-maximal inhibitory concentration: > 100 ug/mL
Compound 4 ended at the assay's limit (the forecaster's own chance of this, stated with the estimate: 85%); the middle value lies on the limit itself.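

No step can be read from compound 2 to compound 4, because both values are limits and not numbers: the limit of > 100 ug/mL in this assay, at which 4 of the 4 values shown sit.

The compounds shown leave open what number any of them would give, and so whether 3-bromophenyl in place of 1-methylbutoxy changes the read-out at all.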